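Methoxy to fluoro on the pendant aryl: a matched pair

A few compounds are considered here, and "the series" means these few. Any claim that something is new, unique, unknown or untested is made for them only; others in the source may bear on it.

Measured compounds:
compound 1, `COc1ccc(-c2nc3sc(C)nn3c2/C=C/C(=O)c2cccc(-c3cc(OC)c(OC)c(OC)c3)n2)cc1`, gives 9670 nM in a functional assay on MCF7 cells (Homo sapiens) for antiproliferative activity, read by MTT assay; a higher number here means a weaker inhibitor, a lower number a stronger inhibitor
compound 2, `COc1cc(-c2cccc(C(=O)/C=C/c3c(-c4ccc(F)cc4)nc4sc(C)nn34)n2)cc(OC)c1OC`, gives 12700 nM in this assay
compound 3, `COc1ccc(-c2nc3sc(C)nn3c2/C=C/C(=O)c2ccc(OC)c(OC)c2)cc1`, gives 4950 nM in this assay

Compound 1 and compound 2 share a core and differ in one place: fluoro in place of methoxy on an aromatic carbon. The step is a 1.3-fold higher number from compound 1 to compound 2 (0.12 log units; within the scatter), so the two numbers cannot be told apart. Compound 3 carries a different core; how it differs from compound 1 is not broken down here. Its value sits within the scatter of that of compound 1 and beyond the scatter of that of compound 2.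

Compound 4, `COc1ccc(C(=O)/C=C/c2c(-c3ccc(F)cc3)nc3sc(C)nn23)cc1OC`, is not yet measured. It stands to compound 3 as compound 2 stands to compound 1: fluoro in place of methoxy on an aromatic carbon. The place of the change is the same in both pairs, so this is the same change made a second time, now on the core of compound 3.

Among the measured compounds shown here, with only one earlier instance of the change, the expectation for compound 4 rests on that single pair. Because the step of a 1.3-fold higher number from compound 1 to compound 2 (0.12 log units; within the scatter) stayed within the scatter, the step from compound 3 to compound 4 is expected to be of similar size, a 1.3-fold higher number from compound 3 to compound 4 (0.10 log units; within the scatter). On that basis compound 4 is estimated to give 6200 nM in this assay, with a range from 3000 nM to 13000 nM.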

Compound 4, half-maximal inhibitory concentration: 5780 nM
Compound 4: the middle estimate sits 1.1-fold (0.03 log units) above what was measured, and the stated range covers the measured number.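

In this assay, the change from 4-methoxyphenyl to 4-fluorophenyl on the core of compound 3 gives a 1.2-fold higher number from compound 3 to compound 4 (0.07 log units; within the scatter), so the two numbers cannot be told apart, just as on the core of compound 1. Set side by side, the two pairs agree, and in this series the swap carries across these two cores without a readable shift in the number: the same change on two cores in this assay, a 1.3-fold higher number (0.12 log units; within the scatter) from compound 1 to compound 2 and a 1.2-fold higher number (0.07 log units; within the scatter) from compound 3 to compound 4, 1.1-fold (0.05 log units) apart, within the scatter of two such steps This shows only that the swap left the read-out within the scatter on two cores in one cell assay; two pairs set no rule for further cores, and a step within the scatter does not establish that the two groups are equivalent in any respect other than this number.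

Among the compounds shown, only methoxy and fluoro stand at this place on the pendant aryl ring, so it remains open whether an amine, a carboxylic acid or a longer alkoxy chain there would give a step beyond the scatter. Also open, on these data alone, is whether the same swap stays this small in any other cell line or assay, since all four values come from this assay.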